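Expecting Little Change From a Furan-2-yl Swap

The compounds below may be only part of what the source reports. "The series", "measured", "known", "first", "only" and "open" are said of these compounds alone.

In an ADME assay on NIH3T3 cells (Mus musculus) for cytotoxicity, read by MTT assay, with a stated time of 24 h (a higher number here means a weaker inhibitor, a lower number a stronger inhibitor), compound 1 `O=C(CSc1nnc(-c2ccncc2)o1)N/N=C/c1cccc(F)c1` gives 205000 nM while compound 2 `O=C(CSc1nnc(-c2ccncc2)o1)N/N=C/c1ccccc1F` gives 142000 nM and compound 3 `O=C(CSc1nnc(-c2ccncc2)o1)N/N=C/c1cc(Cl)cc(Cl)c1O` gives 171000 nM on the same shared core. Compound 3 lies within the scatter of both others, so these three cannot be ranked. Compound 4 `O=C(CSc1nnc(-c2ccncc2)o1)N/N=C/c1ccco1` has furan-2-yl in place of 3,5-dichloro-2-hydroxyphenyl on a carbon with a double bond to nitrogen. Three measured steps at this same place bear on the change (a 1.4-fold lower number from compound 1 to compound 2 (0.16 log units; within the scatter)) and (a 1.2-fold lower number from compound 1 to compound 3 (0.08 log units; within the scatter)) and (a 1.2-fold higher number from compound 2 to compound 3 (0.08 log units; within the scatter)). All three stay within the scatter, but none brings in a five-membered aromatic ring, so this guidance is only indirect. No step beyond the scatter is therefore expected in this assay and the estimated step is a 1.1-fold higher number from compound 3 to compound 4 (0.02 log units; within the scatter) in size. For compound 4 the expected value is 180000 nM (estimated range 90000 nM to 350000 nM).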

Compound 4, half-maximal inhibitory concentration: 175000 nM
For compound 4 the middle estimate is 1.0-fold (0.01 log units) above the measured one; the measured number falls inside the stated range.
By their numbers in this assay, from the lowest: compounds 2, 3, 4 and 1 (each within the scatter of the next).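

In this assay, a five-membered aromatic ring now stands on the carbon with a double bond to nitrogen, and all three new steps lie within the scatter: a 1.0-fold higher number from compound 3 to compound 4 (0.01 log units; within the scatter), a 1.2-fold higher number from compound 2 to compound 4 (0.09 log units; within the scatter) and a 1.2-fold lower number from compound 1 to compound 4 (0.07 log units; within the scatter). So among these four compounds, going from 9 heavy atoms in 3,5-dichloro-2-hydroxyphenyl to 5 in furan-2-yl, with both chlorine atoms and the hydrogen-bond donor gone, gives numbers that cannot be told apart, and the six-membered aromatic ring of carbon only is not required for this read-out. Nothing at hand explains why these numbers stay so close.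

Going by these compounds, every group at this place is still an aromatic ring, so what a carboxylic acid, an amine or a plain butyl chain would give there remains open. On these data alone, all four compounds also share the same core, so the effect of a change elsewhere in it remains open too.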